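The compounds below may be only part of what the source reports. "The series", "measured", "known", "first", "only" and "open" are said of these compounds alone.

Values in an ADME assay on RAW264.7 cells (Mus musculus) for cytotoxicity, read by MTT assay; on this read-out lower numbers stand for stronger inhibition and higher numbers for weaker inhibition:
compound 1 `COc1ccc(/C=C/C=C/C(=O)c2ccccc2)cc1`: > 100000 nM (a limit of the assay)
compound 2 `COc1ccc(/C=C/C=C/C(=O)c2cccs2)cc1`: 68500 nM
compound 3 `COc1ccc(/C=C/C=C/C(=O)c2ccco2)cc1`: 76600 nM

Compound 3 gives 76600 nM, and its gap to the other measured number is small: a 1.1-fold higher number from compound 2 to compound 3 (0.05 log units; within the scatter). Next comes compound 4 `CN(C)c1ccc(/C=C/C=C/C(=O)c2ccco2)cc1`, with dimethylamino in place of methoxy on an aromatic carbon. Within the data shown here, no measured step touches this place. The nearest steps are changes on a carbonyl carbon, an at least 1.4-fold lower number from compound 1 to compound 2 (0.16 log units; that floor lies within the scatter) and an at least 1.3-fold lower number from compound 1 to compound 3 (0.11 log units; that floor lies within the scatter), and neither gives a direction. No step beyond the scatter is therefore expected in this assay, though with wide uncertainty. The estimated change is a 1.3-fold lower number from compound 3 to compound 4 (0.11 log units; within the scatter). The estimate for compound 4 is 60000 nM, with an expected range of 20000 nM to 100000 nM.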

Compound 4, half-maximal inhibitory concentration: > 100000 nM
Compound 4: a limit, no number; the forecaster's own chance of this, stated with the estimate: 20%; at least 1.6-fold (0.22 log units) between middle value and limit.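

In this assay, the change from methoxy to dimethylamino gives the first step read on this aromatic carbon, para to a large group: an at least 1.3-fold higher number from compound 3 to compound 4 (0.11 log units; that floor lies within the scatter). Compound 4 gives > 100000 nM, which is a limit of the assay and not a number. The step therefore has only a floor, its true size stays unread, and the change gives no lower number at this position, with the series again at its ceiling: the limit of > 100000 nM in this assay, at which 2 of the 4 values shown sit.

As far as these compounds go, whether a smaller group such as hydroxyl or a primary amine at this carbon would give a number below the limit stays open. So does the effect of dimethylamino when thiophen-2-yl or phenyl sits on the carbonyl carbon.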